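A Ring Exchange from Compound 2 to Compound 3

The compounds below may be only part of what the source reports. "The series", "measured", "known", "first", "only" and "open" are said of these compounds alone.

Of the compounds shown here, two sharing one core have so far been measured in an in vivo ADME assay on the whole organism for pharmacokinetics, with Rattus norvegicus as the target; a higher number here means faster removal of the compound, a lower number slower removal. Compound 1 (`CC(=O)N1CCC(c2ccc(Nc3nc(N)n(-c4ccccn4)n3)cc2)C1`) gives 25.1 mL/min/kg, and compound 2 (`CN1CCN(c2ccc(Nc3nc(N)n(-c4ccccn4)n3)cc2)CC1`) gives 84.4 mL/min/kg, the higher of the two numbers. Within the data shown here, the only measured step is a 3.4-fold higher number from compound 1 to compound 2 (0.53 log units; beyond the scatter), with 4-methylpiperazin-1-yl in place of 1-acetylpyrrolidin-3-yl on an aromatic carbon.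

Compound 3 (`CN1CCC(c2ccc(Nc3nc(N)n(-c4ccccn4)n3)cc2)CC1`) departs from compound 2 at that same place: 1-methylpiperidin-4-yl in place of 4-methylpiperazin-1-yl on an aromatic carbon. Its 1-methylpiperidin-4-yl stands on an aromatic carbon of a six-membered aromatic ring of carbon only, para to a large group. The measured step offers only indirect guidance, as it exchanged a different pair of groups. In the new change, one six-membered non-aromatic ring replaces another, so a smaller step than that one is expected, and its direction is only tentatively downward. The expected change is a 1.4-fold lower number from compound 2 to compound 3 (0.13 log units; within the scatter), and no step beyond the scatter is foreseen. For compound 3 the estimate is 62 mL/min/kg, with an expected range of 32 mL/min/kg to 110 mL/min/kg.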

Compound 3, clearance: 77.1 mL/min/kg
Compound 3: the middle estimate sits 1.2-fold (0.09 log units) below what was measured; the range from low to high includes it.
By their numbers in this assay, from the lowest: compound 1; then compounds 3 and 2 (each within the scatter of the next).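

In this assay, the exchange of a six-membered non-aromatic ring with 2 hetero atoms for one with 1 hetero atom, on an aromatic carbon para to a large group, gives a 1.1-fold lower number from compound 2 to compound 3 (0.04 log units; within the scatter), so this pair shows no measurable difference between 4-methylpiperazin-1-yl and 1-methylpiperidin-4-yl at this place. Against 1-acetylpyrrolidin-3-yl, the new group gives a 3.1-fold higher number from compound 1 to compound 3 (0.49 log units; beyond the scatter), so both six-membered rings now stand beyond the scatter from compound 1, and the earlier step no longer rests on 4-methylpiperazin-1-yl alone. No measured evidence is at hand that would explain either step.

The compounds shown leave open whether the distance from compound 1 goes with the acetyl group or with the ring that carries it, a question that 1-acetylpiperidin-4-yl or 1-methylpyrrolidin-3-yl at the same place would bear on. They also leave open whether a morpholin-4-yl ring or an open-chain dimethylamino group on this aromatic carbon would read with compound 2 and compound 3 or with compound 1.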